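The source may report more compounds than this note shows. Statements on the series, on what has been measured and on what is new or still open speak of the compounds shown alone.

In a functional assay on K562 cells (Homo sapiens) for antiproliferative activity, read by MTT assay, with a stated time of 48 h (on this read-out higher numbers stand for weaker inhibition and lower numbers for stronger inhibition), two compounds of a shared core have been measured. Compound 1 `C=CCN1C(=O)C(=O)c2cc(-c3ccc(OC)cc3)ccc21` gives 390 nM, and compound 2 `COc1ccc(-c2ccc3c(c2)C(=O)C(=O)N3Cc2ccc(Br)cc2)cc1` gives 100 nM. Going by the values given here, compound 2 stands as the lower of the two numbers; the step of a 3.9-fold lower number from compound 1 to compound 2 (0.59 log units; beyond the scatter) separates it from compound 1, which is its only neighbour here.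

The next compound, compound 3 `COc1ccc(-c2ccc3c(c2)C(=O)C(=O)N3Cc2cc(C)cc(C)c2)cc1`, differs from compound 2 only on the group attached to the saturated chain carbon bound to the amide-type nitrogen in the ring: 3,5-dimethylphenyl in place of 4-bromophenyl on a saturated chain carbon bound to an amide-type nitrogen in a ring. Among the compounds with values here, the one measured step, from compound 1 to compound 2, concerns a change at this same place, but it replaces a vinyl by an aryl rather than exchanging one aryl for another, so it bears on the new step only loosely. Within the data shown here, no measured pair shows what the substitution pattern on the phenyl does to this assay. The aryl group is kept, so the number is expected to stay close, with a step of a 1.5-fold higher number from compound 2 to compound 3 (0.18 log units; within the scatter) expected to fall within the scatter. On that basis compound 3 is estimated at 150 nM, within a range from 50 nM to 500 nM.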

Compound 3, half-maximal inhibitory concentration: 140 nM
Compound 3: middle estimate off by 1.1-fold (0.03 log units), on the high side; the measured number falls inside the stated range.
By their numbers in this assay, from the lowest: compounds 2 and 3 (each within the scatter of the next); then compound 1.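

In this assay, putting 3,5-dimethylphenyl in place of 4-bromophenyl on a saturated chain carbon bound to an amide-type nitrogen in a ring gives a 1.4-fold higher number from compound 2 to compound 3 (0.15 log units; within the scatter), so this assay does not tell these two aryl groups apart, even though the bromine is gone and two methyl groups have entered at other ring places. A second aryl group also stands clear of the vinyl of compound 1, with a 2.8-fold lower number from compound 1 to compound 3 (0.44 log units; beyond the scatter), so the lower number is no longer tied to 4-bromophenyl alone but is shared by both aryl compounds shown. Nothing measured here gives a reason for either observation.

With both the substituents and their pattern differing in a single step, the compounds shown cannot separate the contribution of bromine from that of methyl, nor say whether an unsubstituted phenyl would give a similar number. On these data alone, it also remains open how this position would respond to an aryl group bearing an amine or a carboxylic acid, or to a longer chain carrying the aryl group.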